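Clearance notes: three measured compounds, one expected

The source may report more compounds than this note shows. Statements on the series, on what has been measured and on what is new or still open speak of the compounds shown alone.

Measured so far, in an ADME assay on the whole organism (Mus musculus, strain C57BL/6J) for pharmacokinetics, with a stated time of 24 h, at a dose of 2 mg/kg by the intravenous route; on this read-out lower numbers stand for slow clearance and higher numbers for fast clearance:
compound 1, `CCCOc1nc(OCC(C)(C)O)c(-c2ccc(S(C)(=O)=O)cc2)cc1CO`, gives 92.7 mL/min/kg
compound 2, `CCCCOc1nc(OCC(C)(C)O)c(-c2ccc(S(C)(=O)=O)cc2)cc1C(C)O`, gives 48.2 mL/min/kg
compound 3, `CCCCOc1nc(OCC2COC2)c(-c2ccc(S(C)(=O)=O)cc2)cc1CO`, gives 102 mL/min/kg

Compound 3 holds the highest number of the three. Against compound 1 the gap is small and sits within the scatter, so the two cannot be ordered. Against compound 2 the gap is wider and lies beyond the scatter, so compound 2 stands apart with the slower clearance of the set. Among the measured compounds shown here, no single-change pair exists among the measured compounds, so no step size can be read directly from them.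

Compound 4, `CCCCOc1nc(OCC2(O)CCC2)c(-c2ccc(S(C)(=O)=O)cc2)cc1CO`, is the next member, not yet run in this assay. Its difference from compound 3 is 1-hydroxycyclobutyl in place of oxetan-3-yl on a saturated chain carbon bound to an oxygen on an aromatic ring. For the measured compounds named here, the change sits on a saturated chain carbon bound to an oxygen on an aromatic ring, and is the only change between the two.

With only the three numbers to go on, the step from compound 3 to compound 4 is expected to be small, a 1.2-fold lower number from compound 3 to compound 4 (0.08 log units; within the scatter), leaning slightly downward but not beyond the scatter. Compound 1, which also carries a hydroxyl on that side chain and gives 92.7 mL/min/kg, supports this expectation. For compound 4 the estimate is 85 mL/min/kg, with a range from 50 mL/min/kg to 140 mL/min/kg.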

Compound 4, clearance: 100 mL/min/kg
Estimate against measurement, compound 4: 1.2-fold (0.07 log units) below; low and high end bracket the measured number.
By their numbers in this assay, from the lowest: compounds 2, 1, 4 and 3 (each within the scatter of the next, the first and the last beyond it).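

In this assay, among the compounds shown here, putting 1-hydroxycyclobutyl in place of oxetan-3-yl on a saturated chain carbon bound to an oxygen on an aromatic ring gives a 1.0-fold lower number from compound 3 to compound 4 (0.01 log units; within the scatter), the only single-change step that can be read. At this position, the two compounds cannot be told apart on clearance, even though the entering group brings a hydrogen-bond donor that the leaving group lacks and its four-membered ring is of carbon only. Nothing on hand bears on the reason for this outcome.

The compounds shown leave open whether a different kind of group at this position, such as an amine, a carboxylic acid or a longer chain, would stand apart from compound 3 beyond the scatter. For the compounds shown here, also open is whether this exchange would give a step of similar size on a differently substituted core, as this single pair is the only reading of it and cannot support a rule for the series.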